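Ortho-Substituted Aryl Triazoles on a Spiro Core

The source may report more compounds than this note shows. Statements on the series, on what has been measured and on what is new or still open speak of the compounds shown alone.

Compound 1 `CCc1ccccc1-n1nncc1CN1C(=O)C2(C(C#N)=C(N)Oc3c(N)cc4nc5ccccc5nc4c32)c2ccccc21`: 17900 nM
Compound 2 `N#CC1=C(N)Oc2c(N)cc3nc4ccccc4nc3c2C12C(=O)N(Cc1cnnn1-c1ccc(Cl)cc1)c1ccccc12`: > 50000 nM
Compound 3 `N#CC1=C(N)Oc2c(N)cc3nc4ccccc4nc3c2C12C(=O)N(Cc1cnnn1-c1c(F)cccc1F)c1ccccc12`: > 50000 nM

Three compounds sharing one core and differing only in the aryl group on the triazole nitrogen have been tested in a functional assay on HepG2 cells (Homo sapiens) for antiproliferative activity, read by MTT assay, with a stated time of 48 h; a higher number here means a weaker inhibitor, a lower number a stronger inhibitor. Compound 1 gives a measured number, 17900 nM. For compound 2 the assay reports only a limit, > 50000 nM. For compound 3 too the assay reports only a limit, > 50000 nM. Thus compound 3 stands at the limit itself (the limit of > 50000 nM in this assay, at which 2 of the 3 values shown sit), with compound 2 beside it; the change was an at least 2.7-fold higher number from compound 1 to compound 2 (0.44 log units; beyond the scatter) and an at least 2.7-fold higher number from compound 1 to compound 3 (0.44 log units; beyond the scatter), while a step that the two limits leave unreadable from compound 2 to compound 3.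

Compound 4 `Cc1cc(C)c(-n2nncc2CN2C(=O)C3(C(C#N)=C(N)Oc4c(N)cc5nc6ccccc6nc5c43)c3ccccc32)c(C)c1` is the next step from compound 3: 2,4,6-trimethylphenyl in place of 2,6-difluorophenyl on an aromatic nitrogen. Both measured steps from compound 1 show that leaving the 2-ethylphenyl weakens activity, and compound 3 already sits at the limit. Compound 4, with 2,4,6-trimethylphenyl, returns to ring carbons without fluorine, so compound 4 is expected to move back toward compound 1, giving an estimated at least 1.2-fold lower number from compound 3 to compound 4 (0.09 log units; that floor lies within the scatter). For compound 4 the expected value in this assay is 40000 nM, with a range from 12000 nM to 100000 nM, and a limit remains a real possibility.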

Compound 4, half-maximal inhibitory concentration: 48100 nM
Compound 4: middle estimate off by 1.2-fold (0.08 log units), on the low side; the range from low to high includes it.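

In this assay, the 2,4,6-trimethylphenyl on the aromatic nitrogen gives a comparison with the 2-ethylphenyl that has a measured number on both sides, and the difference stands as a real size rather than a floor: a 2.7-fold higher number from compound 1 to compound 4 (0.43 log units; beyond the scatter). Against the other two aryl groups, the same position shows only an at least 1.0-fold lower number from compound 3 to compound 4 (0.01 log units; that floor lies within the scatter) and an at least 1.0-fold lower number from compound 2 to compound 4 (0.01 log units; that floor lies within the scatter), so the 2,4,6-trimethylphenyl cannot be told apart from the 2,6-difluorophenyl or the 4-chlorophenyl in these data. Compound 2 and compound 3 each remain a limit and not a number, so how far either lies from compound 4 cannot be read: the limit of > 50000 nM in this assay, at which 2 of the 4 values shown sit.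

The compounds shown leave open whether a longer chain, such as a propyl in place of the ethyl of the 2-ethylphenyl, or a methoxy group there, would hold or change the number that compound 1 gives, 17900 nM. They also leave open whether an amine or a carboxylic acid on this aryl ring would bring any compound to a lower number than compound 1.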